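The source may report more compounds than this note shows. Statements on the series, on what has been measured and on what is new or still open speak of the compounds shown alone.

Measured so far in a functional assay for antagonist activity at Alpha-1A adrenergic receptor (Oryctolagus cuniculus); on this read-out lower numbers stand for tighter binding and higher numbers for weaker binding:

Compound 1 `CNC(=O)c1cccnc1NCCCN1CCN(c2ccccc2OC)CC1` gives 1 nM.
Compound 2 `COc1ccccc1N1CCN(CCCNc2ncccc2C(=O)N(C)C)CC1` gives 1.59 nM.
Compound 3 `COc1ccccc1N1CCN(CCCNc2ncc(C#N)cc2C(=O)N(C)C)CC1` gives 0.794 nM.

Compound 2 has the largest of these three numbers, yet neither gap sets it apart: the step of a 1.6-fold higher number from compound 1 to compound 2 (0.20 log units; within the scatter) and the step of a 2.0-fold lower number from compound 2 to compound 3 (0.30 log units; within the scatter) both stay within the scatter. Compound 4 `CCOc1ccccc1N1CCN(CCCNc2ncccc2C(=O)N(C)C)CC1` differs from compound 2 by methyl in place of hydrogen on a saturated chain carbon bound to an oxygen on an aromatic ring; read one bond further out, methoxy becomes ethoxy. Within the data shown here, no measured pair tests this spot. The two known steps, each a one-atom change elsewhere on the shared core, moved the number only within the scatter, so in this assay a similarly small shift, in no clear direction, is expected: a 1.0-fold higher number from compound 2 to compound 4 (0.00 log units; within the scatter). Compound 4 is estimated at 1.6 nM, between 0.6 nM and 4.5 nM.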

Compound 4, dissociation constant: 0.501 nM
For compound 4 the middle estimate is 3.2-fold (0.50 log units) above the measured one; measured number below the stated range.
By their numbers in this assay, from the lowest: compounds 4, 3, 1 and 2 (each within the scatter of the next, the first and the last beyond it).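

In this assay, among these compounds, extending methoxy to ethoxy gives a 3.2-fold lower number from compound 2 to compound 4 (0.50 log units; beyond the scatter), the only step so far that lies beyond the scatter. This shows that the 2-methoxyphenyl group is a position where adding one methyl can measurably lower the number, with the change going towards tighter binding. No measurement shown explains this step.

From the compounds shown here alone, whether a longer chain such as propoxy or a branched isopropoxy would lower the number further remains open. So does whether a hydroxy group here would keep binding this tight.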